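The compounds below may be only part of what the source reports. "The series", "measured", "known", "first", "only" and "open" are said of these compounds alone.

Measured so far:
- compound 1 `COc1ccc(C(=O)O[C@H]2CC(C)=C[C@H](O)[C@@]3(C)[C@@H](OC(C)=O)C[C@@](O)(C(C)C)[C@H]23)cc1`: 20500 nM
- compound 2 `COc1ccc(C(=O)O[C@H]2CC(C)=C[C@H](OC(C)=O)[C@]3(C)[C@@H]2[C@](O)(C(C)C)C[C@@H]3O)cc1`: 30300 nM

Both compounds were tested in an ADME assay on PBL cells (Homo sapiens) for cytotoxicity, read by MTT assay, with a stated time of 72 h; a lower number here means a stronger inhibitor, a higher number a weaker inhibitor. Compound 1 gives 20500 nM and compound 2 gives 30300 nM; the two numbers lie within the usual scatter of each other, so neither compound is set apart from the other on this assay, and nothing more than that can be read from the pair. Within the data shown here, no step between measured compounds is on hand for this series.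

Compound 3 `COc1ccc(C(=O)O[C@H]2CC(C)=C[C@H](OC(C)=O)[C@@]3(C)[C@@H](OC(C)=O)C[C@@](O)(C(C)C)[C@H]23)cc1` is the next compound to go into this assay. Its difference from compound 2 is acetyl in place of hydrogen on an oxygen on a saturated carbon. The same change, seen one bond further out, reads hydroxy to acetoxy, and the group that enters carries no ring and no net charge.

Among the measured compounds shown here, nothing among the measured compounds speaks to this change, so the expected step is small, with no direction that can be argued for from the data, and is expected to stay within the scatter: a 1.0-fold lower number from compound 2 to compound 3 (0.00 log units; within the scatter). On that basis compound 3 is estimated at 30000 nM, with a range from 12000 nM to 75000 nM.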

Compound 3, half-maximal inhibitory concentration: 6600 nM
For compound 3 the middle estimate is 4.5-fold (0.66 log units) above the measured one; the measured number lies below the stated range.
By their numbers in this assay, from the lowest: compound 3; then compounds 1 and 2 (each within the scatter of the next).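

In this assay, among these compounds, acetyl in place of hydrogen on an oxygen on a saturated carbon is the first change with a readable effect: a 4.6-fold lower number from compound 2 to compound 3 (0.66 log units; beyond the scatter). Compounds 1 and 2 each lack one of the two acetyl groups of compound 3, and the step on the other oxygen points the same way, a 3.1-fold lower number from compound 1 to compound 3 (0.49 log units; beyond the scatter), so in these three compounds the number drops beyond the scatter only when both oxygens carry acetyl. No measurement on hand offers a reason for either step.

The compounds shown leave open whether this drop needs acetyl itself or would also come with a longer acyl chain such as butanoyl, a benzoyl group or a simple methyl ether on the same oxygens. They also leave open what happens at the hydroxy group that all three compounds keep, for instance if it were acetylated or replaced by an amine, and whether the two-acetyl pattern holds beyond this single set of three compounds.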